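Swapping the Dichlorophenyl Group for a Pyridine

The source may report more compounds than this note shows. Statements on the series, on what has been measured and on what is new or still open speak of the compounds shown alone.

Going by the values given here, in a functional assay on MDA-MB-435 cells (Homo sapiens) for cytotoxicity, read by MTT assay, with a stated time of 72 h (a higher number here means a weaker inhibitor, a lower number a stronger inhibitor), compound 1 (`N[C@H]1CC[C@H](Nc2c(C(=O)NCc3ccc(Cl)cc3Cl)nc(Br)c3cccnc23)CC1`) gives 5800 nM as the only actual number so far. Compound 2 (`C[C@H](Nc1c(C(=O)NCc2ccc(F)cc2)nc(Br)c2cccnc12)c1ccccc1`) stands at > 20000 nM which is a limit of the assay and not a number. Compound 3 (`N[C@H]1CC[C@H](Nc2c(C(=O)NCc3ccccn3)nc(Br)c3cccnc23)CC1`) keeps the core of compound 1 and differs in one place. The change is pyridin-2-yl in place of 2,4-dichlorophenyl on a saturated chain carbon bound to an amide-type nitrogen with pyridin-2-yl in place of 2,4-dichlorophenyl on a saturated chain carbon bound to an amide-type nitrogen. Among the compounds with values here, no measured pair tests this change, which leaves compound 1 at 5800 nM as the sole anchor for any expectation. A moderate move towards weaker inhibition is expected, with an estimated size of a 1.9-fold higher number from compound 1 to compound 3 (0.28 log units; within the scatter) and considerable uncertainty. In this assay the estimated value for compound 3 is 11000 nM with an expected range (4500 nM to 20000 nM).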

Compound 3, half-maximal inhibitory concentration: 4000 nM
For compound 3 the middle estimate is 2.8-fold (0.44 log units) above the measured one; measured number below the stated range.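

With the shared core held constant, pyridin-2-yl in place of 2,4-dichlorophenyl on a saturated chain carbon bound to an amide-type nitrogen gives, in this assay, a 1.5-fold lower number from compound 1 to compound 3 (0.16 log units; within the scatter). Going by these compounds alone, this is the first comparison at this position that differs in one place only, and it shows that both chlorines can go and a ring nitrogen can enter without the read-out moving beyond the usual scatter, so the 2,4-dichlorophenyl group is not needed to hold this level of activity. Nothing measured here gives a reason for this outcome.

From the compounds shown here alone, only this one replacement can be read at this position, so it remains open how this assay would respond to a plain phenyl, a pyridin-3-yl or a pyridin-4-yl group there. Going by these compounds, it is equally open whether a saturated ring such as cyclohexyl, or a carboxylic acid, would be accepted at the same place.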